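Rat microsomal stability notes: from compound 2 toward compound 4

This account rests on a few compounds, and the source may have more. Where it says the series, first, only, none or still open, it means among the compounds named here.

Measured so far:
compound 1, `C[C@@H]1C=NN(C(=O)C(C)(C)C)[C@@H]1c1ccccc1`: 0.2 h
compound 2, `O=C(C1CCN(C(=O)C(F)(F)F)CC1)N1N=CCC1c1ccccc1`: 0.483 h
compound 3, `O=C(C1CCCCC1)N1N=CCC1c1ccccc1`: 0.0833 h

In an ADME assay on microsomes (Rattus norvegicus) for metabolic stability (a higher number here means that the compound lasts longer, a lower number that the compound disappears faster), compound 2 gives 0.483 h, the highest of the three numbers. Compound 1 stands nearest to it with 0.2 h, compound 3 furthest with 0.0833 h; both gaps lie beyond the scatter. Among the compounds with values here, no two measured compounds differ in a single place, so no measured step is available in this set.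

Compound 4, `O=C(c1cn[nH]c1)N1CCC(C(=O)N2N=CCC2c2ccccc2)CC1`, is not yet measured in this assay. It differs from compound 2 in one place: 1H-pyrazol-4-yl in place of trifluoromethyl on a carbonyl carbon. The change sits on a carbonyl carbon whose other neighbours are an amide-type nitrogen in a ring. Within the data shown here, nothing among the measured compounds tracks this exchange, so the outlook rests on compound 2 alone. The expected step is a 1.2-fold lower number from compound 2 to compound 4 (0.08 log units; within the scatter), none beyond the scatter in either direction, with a wide range to reflect the lack of any comparable step. Compound 4 is therefore estimated at 0.4 h, between 0.15 h and 1 h.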

Compound 4, half-life: > 2.75 h
Compound 4 ended at the assay's limit; the forecaster's own chance of this, stated with the estimate: 10%; middle value at least 6.8-fold (0.83 log units) from the limit.
By their numbers in this assay, from the lowest: compound 3; then compound 1; then compound 2. At a limit, above all of these: compound 4.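

Compound 4 gives no number in this assay, only a limit: the limit of > 2.75 h in this assay, at which 1 of the 4 values shown sits. Within the data shown here, replacing trifluoromethyl with 1H-pyrazol-4-yl on this carbonyl carbon gives an at least 5.6-fold higher number from compound 2 to compound 4 (0.75 log units; beyond the scatter), the first single-place step in the set. The earlier compounds shown here could not show that the group on this carbonyl carbon matters, but this exchange moves the half-life beyond the scatter, and the full size of the step remains unfixed.

A single exchange does not separate the contribution of the entering aromatic ring, its hydrogen-bond donor or the departure of trifluoromethyl. As far as these compounds go, whether a phenyl ring or a dimethylamino group on this carbonyl carbon would give a step of similar size remains open, as does whether the same exchange would hold on a different core.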